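A few compounds are considered here, and "the series" means these few. Any claim that something is new, unique, unknown or untested is made for them only; others in the source may bear on it.

Measured compounds:
- compound 1 `COc1ccc(-c2cc(/C=C/C(=O)c3ccc(N)cc3)[nH]n2)cc1`: 1000 nM
- compound 2 `COc1cc(-c2cc(/C=C/C(=O)c3ccc(N)cc3)[nH]n2)cc(OC)c1OC`: 1370 nM
- compound 3 `COc1cc(-c2cc(/C=C/C(=O)c3ccc(Cl)c(Cl)c3)[nH]n2)cc(OC)c1OC`: 4290 nM

In a functional assay on HCT-15 cells (Homo sapiens) for inhibition, read by sulforhodamine B assay, with a stated time of 48 h (a higher number here means a weaker inhibitor of growth, a lower number a stronger inhibitor of growth), compound 2 gives 1370 nM, the second highest number of the three; its nearest neighbour is compound 1, within the scatter, and its furthest is compound 3, beyond it. Within the data shown here, the only measured step from compound 2 is a 3.1-fold higher number from compound 2 to compound 3 (0.50 log units; beyond the scatter), a change on the carbonyl side of the molecule. Compound 4 `COc1ccc(-c2cc(/C=C/C(=O)c3ccc(N)cc3)[nH]n2)cc1OC` differs from compound 2 by hydrogen in place of methoxy on an aromatic carbon, on the other aryl ring. Among the measured compounds shown here, no measured step touches that ring directly; compound 1 and compound 2, which differ in methoxy count on the same ring, sit within the scatter of each other. Compound 4 is therefore expected to show a 1.1-fold lower number from compound 2 to compound 4 (0.06 log units; within the scatter), no step beyond the scatter, with an estimate of 1200 nM (range 500 nM to 2800 nM).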

Compound 4, concentration for 50% growth inhibition: 1700 nM
Estimate against measurement, compound 4: 1.4-fold (0.15 log units) below; the measured number falls inside the stated range.
By their numbers in this assay, from the lowest: compounds 1, 2 and 4 (each within the scatter of the next); then compound 3.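

In this assay, hydrogen in place of methoxy on an aromatic carbon gives a 1.2-fold higher number from compound 2 to compound 4 (0.09 log units; within the scatter), and methoxy in place of hydrogen on an aromatic carbon gives a 1.7-fold higher number from compound 1 to compound 4 (0.23 log units; within the scatter). Across compounds 1, 2 and 4, then, the number of methoxy groups on this ring leaves the values within the scatter of one another. Nothing available explains this result. On these data alone, whether a different group on this ring, such as a hydroxyl or a fluorine, would behave like methoxy remains open. So does whether a ring with no methoxy at all would stay within the scatter.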